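Allyl to Propargyl Thioether in a Phenolic Amide Series

The compounds below may be only part of what the source reports. "The series", "measured", "known", "first", "only" and "open" are said of these compounds alone.

Measured compounds and their values:
Compound 1 `C=CCSC[C@H](NC(=O)c1cc(O)c(O)c(O)c1)C(=O)OC`: 52100 nM
Compound 2 `C=CCSC[C@H](NC(=O)c1cc(O)cc(O)c1)C(=O)OC`: 58500 nM

Both compounds share one core, an amide built from a hydroxylated benzoic acid and a sulfur-bearing amino ester. In an assay on RAW264.7 cells for antagonist activity at Toll-like receptor 2 (Mus musculus), read by Griess assay, with a stated time of 24 h (on this read-out higher numbers stand for weaker inhibition and lower numbers for stronger inhibition), compound 2 gives 58500 nM. For the measured compounds named here, its only neighbour is compound 1, and the step of a 1.1-fold higher number from compound 1 to compound 2 (0.05 log units; within the scatter) is within the scatter, so the two compounds cannot be told apart, and neither can be called the stronger inhibitor.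

Compound 3 `C#CCSC[C@H](NC(=O)c1cc(O)cc(O)c1)C(=O)OC` is a new member of this pair. It differs from compound 2 by ethynyl in place of vinyl on a saturated chain carbon bound to a sulfur. Going by the values given here, the single measured step, a 1.1-fold higher number from compound 1 to compound 2 (0.05 log units; within the scatter), concerns a hydroxy on the aromatic ring, not the chain at sulfur, so it does not bear on this change. Among the compounds with values here, no measured step touches the sulfur-bound chain at all, so the expectation is a step of a 1.0-fold lower number from compound 2 to compound 3 (0.00 log units; within the scatter), nothing beyond the scatter. For compound 3 in this assay the estimated value is 58000 nM, with a range from 22000 nM to 150000 nM.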

Compound 3, half-maximal inhibitory concentration: 41800 nM
For compound 3 the middle estimate is 1.4-fold (0.14 log units) above the measured one; the measured number falls inside the stated range.
By their numbers in this assay, from the lowest: compounds 3, 1 and 2 (each within the scatter of the next).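

In this assay, for the compounds shown here, replacing allyl with propargyl on the sulfur gives a 1.4-fold lower number from compound 2 to compound 3 (0.15 log units; within the scatter) and is the first measured step at the sulfur-bound chain. At this place, on a saturated chain carbon bound to a sulfur, the read-out does not separate vinyl from ethynyl, or a double bond from a triple bond. No outside data bear on why this is so.

What the compounds shown leave open is whether the sulfur-bound chain matters more with a larger change: a longer chain, or a chain ending in an amine or a carboxylic acid, might or might not move the number beyond the scatter. Propargyl also appears here only with the hydroxy pattern of compound 2, so its result with the extra hydroxy of compound 1 remains unknown.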